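The source may hold more compounds than are shown below. What is called first, only, known or untested is meant among the compounds shown, and "the series" means these compounds.

The measured compounds and their values:

compound 1, `O=C(Nc1cc(-c2ccccc2)nn1-c1ccccc1)c1cccc(C(F)(F)F)c1`: 228 nM
compound 2, `O=C(Nc1cc(-c2ccccc2Cl)nn1-c1ccccc1)c1ccccc1`: 2290 nM
compound 3, `O=C(Nc1cc(-c2ccccc2)nn1-c1cccc(Br)c1)c1ccccc1`: 400 nM

In a functional assay on cells for positive allosteric modulation of metabotropic glutamate receptor 5 (Rattus norvegicus), read by calcium flux (on this read-out lower numbers stand for an effect already at smaller amounts and higher numbers for an effect only at larger amounts of compound), compound 1 gives the lowest of the three numbers. Compound 3 comes nearest to it, and the two values lie within the scatter of each other, so nothing separates them. Compound 2 stands furthest away, with a number beyond the scatter above that of compound 1.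

Compound 4, `Cc1ccc(C(=O)Nc2cc(-c3ccccc3)nn2-c2ccccc2)cn1`, has not yet been measured. It differs from compound 1 in one place:

6-methylpyridin-3-yl in place of 3-(trifluoromethyl)phenyl on a carbonyl carbon

Within the data shown here, no step between measured compounds touches this position on the carbonyl carbon, so the only ground for an expectation is the range of the three numbers themselves. The step from compound 1 to compound 4 in this assay is expected to be a modest rise in the number, a 2.4-fold higher number from compound 1 to compound 4 (0.38 log units; beyond the scatter), with a wide uncertainty in both directions. Compound 4 is therefore estimated at 550 nM, within a range from 150 nM to 2000 nM.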

Compound 4, half-maximal effective concentration: 280 nM
The estimate for compound 4 lay 2.0-fold (0.29 log units) above the measured number; the range from low to high includes it.
By their numbers in this assay, from the lowest: compounds 1, 4 and 3 (each within the scatter of the next); then compound 2.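

In this assay, putting 6-methylpyridin-3-yl in place of 3-(trifluoromethyl)phenyl on the carbonyl carbon gives a 1.2-fold higher number from compound 1 to compound 4 (0.09 log units; within the scatter), so this change does not separate the two compounds. Among these compounds, this is the first reading at this position, and it shows that trifluoromethyl is not required here for a value in this range: a ring with one hetero atom and one hydrogen-bond acceptor, and with fewer heavy atoms, stands in for a carbon-only ring with no acceptor. Nothing at hand offers a reason for this result.

The compounds shown do not separate the contribution of the methyl group from that of the ring nitrogen in 6-methylpyridin-3-yl. Also open, on these data alone, is how this position responds to a group of another kind, such as a carboxylic acid, a morpholine or a cyclohexyl ring.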